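The source may hold more compounds than are shown below. What is called first, only, known or untested is meant among the compounds shown, and "the series" means these compounds.

Measured so far in an assay on isolated protein for inhibition of Ephrin type-A receptor 2 (Homo sapiens), read by thermal shift assay, tested at 10 uM; a lower number here means that the compound stabilises the target less, a higher number that the compound stabilises the target more against heat:
Compound 1, `CC(C)(C)c1cc(NC(=O)Nc2ccc(Cl)cc2)n(-c2ccc(OC(F)(F)F)cc2)n1`: 0.9 degrees C
Compound 2, `O=C(Nc1ccc(Cl)cc1)Nc1cc(C2CC2)nn1-c1ccc(OC(F)(F)F)cc1`: 0.2 degrees C

For the measured compounds named here, compound 1 holds the higher of the two numbers in this assay, with compound 2 as its only neighbour; the step of a number 0.70 degrees C lower from compound 1 to compound 2 (within the scatter) is within the scatter, so the two compounds cannot be told apart on these data. Compound 3, `CC(C)(C)c1cc(NC(=O)Nc2ccc(Cl)cc2)n(-c2ccc(NC(=O)C3CC3)cc2)n1`, keeps the tert-butyl of compound 1 and changes the other end of the molecule: (cyclopropylcarbonyl)amino in place of trifluoromethoxy on an aromatic carbon. Going by the values given here, no measured step touches this position; the one recorded step, a number 0.70 degrees C lower from compound 1 to compound 2 (within the scatter), concerns the tert-butyl and cyclopropyl end and was itself within the scatter. There is therefore no measured basis for expecting a change in this assay beyond the scatter in either direction. The account expects compound 3 to come out near compound 1, at about 0.8 degrees C with a range of -0.6 degrees C to 2.2 degrees C. The expected step of a number 0.10 degrees C lower from compound 1 to compound 3 (within the scatter) is thus essentially none, with the range left wide to reflect the absence of any bearing measurement.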

Compound 3, shift of the target's melting temperature: 3 degrees C
The estimate for compound 3 lay 2.2 degrees C below the measured number; the measured number lies above the stated range.
By their numbers in this assay, from the lowest: compounds 2 and 1 (each within the scatter of the next); then compound 3.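

In this assay, this position, on an aromatic carbon para to a large group, proves able to move the number: (cyclopropylcarbonyl)amino in place of trifluoromethoxy gives a number 2.1 degrees C higher from compound 1 to compound 3 (beyond the scatter), the only step shown that lies beyond the scatter. The entering group brings a hydrogen-bond donor and a three-membered ring, neither of which trifluoromethoxy has, but this single pair cannot separate the contributions of those features. No measurement at hand explains why the number rises.

The compounds shown leave open whether a plain amine, an acetylamino group or a longer acyl chain on this carbon would give a similar number. They also leave open whether the step would hold with cyclopropyl in place of tert-butyl at the other end of the molecule.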